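Aryl ketone exchange on the ethenyl arm: cytotoxicity outlook

The source may report more compounds than this note shows. Statements on the series, on what has been measured and on what is new or still open speak of the compounds shown alone.

Compound 2 `COC(=O)c1cc(-c2cccc(NC(=O)c3ccc(/C=C/C(=O)c4ccccc4Br)cc3)c2)on1` carries a 2-((2-bromophenyl)carbonyl)ethenyl group on the shared core. In an ADME assay on Vero cells (Chlorocebus sabaeus) for cytotoxicity, read by MTT assay, with a stated time of 72 h (a lower number here means that less compound is tolerated, a higher number that more compound is tolerated), compound 2 returns only a limit, > 40 ug/mL. Compound 1 `COC(=O)c1cc(-c2cccc(NC(=O)c3ccc(C4OC4C(=O)c4ccc(Cl)cc4)cc3)c2)on1`, which carries a 3-((4-chlorophenyl)carbonyl)oxiran-2-yl group at the same place, likewise returns only a limit in this assay, > 20 ug/mL. For the measured compounds named here, the single measured step, a step that the two limits leave unreadable from compound 1 to compound 2, therefore cannot be read, as the limit of > 20 ug/mL in this assay, at which 1 of the 2 values shown sits, and the limit of > 40 ug/mL in this assay, at which 1 of the 2 values shown sits, show; neither value is a number.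

Compound 3 `COC(=O)c1cc(-c2cccc(NC(=O)c3ccc(/C=C/C(=O)c4cccc(Cl)c4)cc3)c2)on1` differs from compound 2 by 3-chlorophenyl in place of 2-bromophenyl on a carbonyl carbon. Going by the values given here, no measured step bears directly on an exchange of one phenyl group for another on this carbonyl carbon, and the one step available is itself unreadable. The expectation for compound 3 in this assay is therefore a step that the limit leaves unreadable from compound 2 to compound 3, with no direction beyond the scatter, and most likely another limit rather than a number. Compound 3 is estimated at 50 ug/mL, expected to fall within 25 ug/mL to 100 ug/mL.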

Compound 3, half-maximal cytotoxic concentration: > 2.5 ug/mL
Compound 3: only a limit was reported; the forecaster's own chance of this, stated with the estimate: 75%; the middle value lies beyond the limit too.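

In this assay compound 3 returns only a limit, > 2.5 ug/mL, and not a number. For the compounds shown here, compound 1 and compound 2 also stand at limits, so no step linking compound 3 to either can be read. The compounds shown leave open whether 3-chlorophenyl in place of 2-bromophenyl on a carbonyl carbon alters tolerance at all.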